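Moving the Chlorine on the Benzyl Group

The source may report more compounds than this note shows. Statements on the series, on what has been measured and on what is new or still open speak of the compounds shown alone.

Compound 3 `Cc1ccc2[nH]c(-n3[nH]c(C)c(Cc4ccc(Cl)cc4)c3=O)nc2c1` carries a 4-chlorobenzyl group on the shared core. Going by the values given here, in an assay on isolated protein for inhibition of alpha-ketoglutarate-dependent dioxygenase alkB homolog 3 (Homo sapiens), read by polymerase chain reaction, with a stated time of 1 h (a higher number here means a weaker inhibitor, a lower number a stronger inhibitor), compound 3 gives 750 nM, one of only two numbers measured. The other belongs to compound 2 `Cc1ccc2[nH]c(-n3[nH]c(C)c(Cc4ccc(Cl)c(Cl)c4)c3=O)nc2c1`, which gives 720 nM and sits within the scatter of compound 3: a 1.0-fold higher number from compound 2 to compound 3 (0.02 log units; within the scatter). Compound 1 `Cc1[nH]n(-c2nc3ccccc3[nH]2)c(=O)c1Cc1ccccc1Cl`, which carries the 2-chlorobenzyl group but lacks the methyl on the core, gives only a limit, > 10000 nM. Compound 4 `Cc1ccc2[nH]c(-n3[nH]c(C)c(Cc4ccccc4Cl)c3=O)nc2c1` is unmeasured; its change from compound 3 is 2-chlorophenyl in place of 4-chlorophenyl on a saturated chain carbon bound to an aromatic carbon. No measured step covers this move directly, and the single step shown was within the scatter. Because compound 1 gives > 10000 nM, a weaker result is expected for compound 4. Compound 4 is therefore estimated at 5000 nM, with a range from 1500 nM to 20000 nM, an expected step of a 6.7-fold higher number from compound 3 to compound 4 (0.82 log units; beyond the scatter).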

Compound 4, half-maximal inhibitory concentration: 910 nM
Compound 4: the middle estimate sits 5.5-fold (0.74 log units) above what was measured; the whole stated range lies above it.
By their numbers in this assay, from the lowest: compounds 2, 3 and 4 (each within the scatter of the next). At a limit, above all of these: compound 1.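

In this assay, 2-chlorobenzyl and 4-chlorobenzyl read alike (a 1.2-fold higher number from compound 3 to compound 4 (0.08 log units; within the scatter)), and compound 4 also sits with the 3,4-dichlorophenyl group of compound 2 (a 1.3-fold higher number from compound 2 to compound 4 (0.10 log units; within the scatter)). The 2-chlorobenzyl group alone therefore does not account for the weak result of compound 1, and the one difference left is methyl in place of hydrogen on an aromatic carbon (an at least 10-fold lower number from compound 1 to compound 4 (1.04 log units; beyond the scatter)). The value of compound 1 is a limit, not a number: the limit of > 10000 nM in this assay, at which 1 of the 4 values shown sits.

Still open, from the compounds shown here alone, is how a benzyl group carrying a methoxy or a carboxylic acid would read. A longer chain in place of the benzyl group is equally untested here.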